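Benzyloxy to allyloxy on the chromane oxygen: compound 4

A few compounds are considered here, and "the series" means these few. Any claim that something is new, unique, unknown or untested is made for them only; others in the source may bear on it.

Measured so far in a functional assay on MCF7 cells (Homo sapiens), tested at 2.5 uM; on this read-out higher numbers stand for a weaker effect at the one concentration tested and lower numbers for a stronger effect:
compound 1, `CCOc1cc(/C=C2\SC(=O)NC2=O)ccc1OCC1(C)CCc2c(C)c(OCC=C(C)C)c(C)c(C)c2O1`: 107%
compound 2, `CC(C)=CCOc1c(C)c(C)c2c(c1C)CCC(C)(COc1ccc(/C=C3\SC(=O)NC3=O)cc1Br)O2`: 96%
compound 3, `Cc1c(C)c2c(c(C)c1OCc1ccccc1)CCC(C)(COc1ccc(/C=C3\SC(=O)NC3=O)cc1)O2`: 85%

Compound 3 holds the lowest number of the three in this assay; compound 2 sits a number 11 percentage points lower from compound 1 to compound 2 (beyond the scatter) than compound 1, and compound 3 in turn lies a further step below compound 2 and well below compound 1, both beyond the scatter.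

Compound 4, `C=CCOc1c(C)c(C)c2c(c1C)CCC(C)(COc1ccc(/C=C3\SC(=O)NC3=O)cc1)O2`, differs from compound 3 in one place: vinyl in place of phenyl on a saturated chain carbon bound to an oxygen on an aromatic ring. Within the data shown here, no measured pair shows this change. Among the measured compounds shown here, the only single-point step on record, from compound 1 to compound 2, concerns an unrelated position and is modest in size; it offers no direct guide. Compounds 1 and 2 carry a different chain on the same aromatic oxygen and both give higher numbers than compound 3, but they differ from compound 3 in more than one place, so nothing firm follows.

The expectation is therefore a small shift, likely within the scatter, a number 5 percentage points higher from compound 3 to compound 4 (within the scatter), with compound 4 estimated at 90%, range 75% to 105%.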

Compound 4, a percentage reported as activity, at one concentration (the size of the read-out at that concentration, not a potency): 45%
Estimate against measurement, compound 4: 45 percentage points above; measured number outside the range, below it.
By their numbers in this assay, from the lowest: compound 4; then compound 3; then compound 2; then compound 1.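

In this assay, the group on the saturated chain carbon bound to an oxygen on an aromatic ring turns out to be a sensitive point in the series: vinyl in place of phenyl gives a number 40 percentage points lower from compound 3 to compound 4 (beyond the scatter), a large step beyond the scatter. Among these compounds, the earlier record held only the modest bromo-for-ethoxy step at an unrelated position, so this is the first sign that benzyloxy to allyloxy can move the read-out towards a stronger effect at the one concentration tested. Nothing available here explains the step.

On these data alone, whether it follows from losing the aromatic ring or from gaining the double bond stays open; a saturated propyl group in place of allyl would separate the two. Also open, as far as these compounds go, is whether allyl keeps this effect alongside the bromo of compound 2 or the ethoxy of compound 1.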